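The source may report more compounds than this note shows. Statements on the series, on what has been measured and on what is new or still open speak of the compounds shown alone.

Compound 1 `CSc1nnc(COc2cc(C)c3c(C)cc(=O)oc3c2)o1` was tested in a functional assay on MCF7 cells (Homo sapiens) for antiproliferative activity, read by MTT assay, with a stated time of 24 h; on this read-out higher numbers stand for weaker inhibition and lower numbers for stronger inhibition. There compound 1 gives > 100000 nM, which is a limit of the assay rather than a number, so compound 1 stands at the limit of > 100000 nM in this assay, at which 1 of the 2 values shown sits. For the measured compounds named here, compound 2 `Cc1cc(OCc2nnc(SCc3cccc(F)c3)o2)cc2oc(=O)cc(C)c12` is the only other compound with a result, and in this assay compound 2 gives 26000 nM. Going by the values given here, the single measured step, an at least 3.8-fold lower number from compound 1 to compound 2 (0.58 log units; beyond the scatter), alters a different part of the molecule. Compound 3 `CCS(=O)(=O)c1nnc(COc2cc(C)c3c(C)cc(=O)oc3c2)o1` differs from compound 1 by ethylsulfonyl in place of methylsulfanyl on an aromatic carbon. Among the compounds with values here, no measured step touches that aromatic carbon of the shared core, so the two results say nothing about whether this exchange moves the number, and no step beyond the scatter is expected in this assay. Compound 3 is therefore expected to stay near the limit, at roughly 150000 nM, between 30000 nM and 600000 nM. That estimate means an expected step that the limit leaves unreadable from compound 1 to compound 3.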

Compound 3, half-maximal inhibitory concentration: > 100000 nM
Compound 3 gave a limit, no number (the forecaster's own chance of this, stated with the estimate: 70%); the middle value does not contradict the limit.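

In this assay compound 3 gives > 100000 nM, which is a limit of the assay and not a number. Compound 1 also gives a limit, so the step from methylsulfanyl to ethylsulfonyl on this aromatic carbon cannot be read, and neither group can be ranked against the other. Ethylsulfonyl in place of (3-fluorobenzyl)sulfanyl gives an at least 3.8-fold higher number from compound 2 to compound 3 (0.58 log units; beyond the scatter), so among the three groups shown at this carbon, only (3-fluorobenzyl)sulfanyl gives a readable number.

Going by these compounds, it remains open whether that number depends on the fluorine, which a plain benzylsulfanyl group would test, or on the sulfur link, which a benzylamine on the same carbon would test. Also open, on these data alone, is whether compound 2, at 26000 nM, can be improved on by any group at this carbon.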